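Swapping one group on the core of compound 2

The source may hold more compounds than are shown below. What is called first, only, known or untested is meant among the compounds shown, and "the series" means these compounds.

Of the compounds shown here, three have been measured in a physicochemical assay for lipophilicity, using the shake flask method, in phosphate buffer, measured as octanol-water partition, with a stated time of 30 min, at pH 7.4; on this read-out lower numbers stand for lower lipophilicity and higher numbers for higher lipophilicity. Compound 1 (`O=C(Nc1ccccc1)c1cnc(NCc2c(F)ccc3c2CCO3)n2cnnc12`) gives 4.1. Compound 2 (`Cc1ncc(-c2cnc(NCc3c(F)ccc4c3CCO4)c3cn[nH]c(=O)c23)n1C`) gives 1.9, and compound 3 (`CN(c1ccn(C)n1)c1cnc(NCc2c(F)ccc3c2CCO3)n2cnnc12`) gives 1.8. Compound 2 therefore lies far under compound 1, beyond the scatter, while compound 2 and compound 3 agree within the scatter.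

Compound 4 (`CN(c1ccn(C)n1)c1cnc(NCc2c(F)ccc3c2CCO3)c2cn[nH]c(=O)c12`) has not yet been measured in this assay. It keeps the core of compound 2 but carries methyl(1-methyl-1H-pyrazol-3-yl)amino in place of 1,2-dimethyl-1H-imidazol-5-yl on an aromatic carbon.

Going by the values given here, only one measured step involves the entering group, and it is large and beyond the scatter: a number 2.30 log units lower from compound 1 to compound 3 (beyond the scatter). There, however, the group replaced is phenylcarbamoyl, so this step says little about the loss of 1,2-dimethyl-1H-imidazol-5-yl. Among the compounds with values here, no measured step shows that loss directly. The closer guide is compound 3, which carries the entering group on a different core and gives 1.8, a value matching that of compound 2 within the scatter. On that basis, no change beyond the scatter is expected, and the estimated step is a number 0.20 log units higher from compound 2 to compound 4 (within the scatter). For compound 4 the expected value is 2.1, with an estimated range from 1.6 to 2.6.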

Compound 4, distribution coefficient: 2.4
Estimate against measurement, compound 4: 0.30 log units below, and the stated range covers the measured number.
By their numbers in this assay, from the lowest: compounds 3 and 2 (each within the scatter of the next); then compound 4; then compound 1.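

Going by these compounds alone, on the core of compound 2, on an aromatic carbon of a six-membered aromatic ring with 1 nitrogen, replacing 1,2-dimethyl-1H-imidazol-5-yl with methyl(1-methyl-1H-pyrazol-3-yl)amino moves the read-out of this assay by a number 0.50 log units higher from compound 2 to compound 4 (beyond the scatter), so this position does respond to the change, and the loss of 1,2-dimethyl-1H-imidazol-5-yl can now be read directly for the first time. The entering group also now has a second step, and it runs the opposite way to a number 2.30 log units lower from compound 1 to compound 3 (beyond the scatter), showing across these two steps that its arrival does not fix the direction of the change, which differs with the group that leaves and the core that carries it. No measurement at hand explains the rise at this position.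

The step exchanges the ring and its link to the core together, so the compounds shown leave open how much belongs to the five-membered ring and how much to the methylated amine nitrogen. A directly attached 1-methyl-1H-pyrazol-3-yl, or a secondary amine linker carrying the same ring, would separate the two contributions.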